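The compounds below may be only part of what the source reports. "The series", "measured", "known", "first", "only" and "open" are said of these compounds alone.

The series is two compounds with a shared core, compound 1 `CCCCCCc1cn(C(c2ccccc2)c2cc3cc(Br)ccc3nc2OC)nn1` and compound 2 `CCCCc1cn(C(c2ccccc2)c2cc3cc(Br)ccc3nc2OC)nn1`, both tested in an ADME assay on SK-OV-3 cells (Homo sapiens) for cytotoxicity, read by sulforhodamine B assay, with a stated time of 48 h, tested at 10 uM; a higher number here means more inhibition at the concentration tested (going by the name of the read-out), a lower number less inhibition. Compound 1 gives 7.17% in this assay, and compound 2 gives 11.1%. The one step in the set, a number 3.9 percentage points higher from compound 1 to compound 2 (within the scatter), is the shortening of a chain; it left the read-out essentially unchanged, so compound 2 and compound 1 are indistinguishable on the numbers shown, both with little inhibition at the concentration tested.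

Compound 3 `COc1nc2ccc(Br)cc2cc1C(c1ccccc1)n1cc(-c2ccccc2F)nn1` is the next compound. It differs from compound 2 by 2-fluorophenyl in place of butyl on an aromatic carbon. For the measured compounds named here, no measured step bears on this change: the only step in the set exchanged one chain for a shorter one, not a chain for a ring, and it was within the scatter. With nothing to point to a change beyond the scatter, compound 3 is expected to give 14% in this assay, within the range 0% to 40%. The step this estimate means, a number 2.9 percentage points higher from compound 2 to compound 3 (within the scatter), is expected to fall within the scatter of the measurement.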

Compound 3, a percentage reported as inhibition, at one concentration (the size of the read-out at that concentration, not a potency): 7.33%
Compound 3: middle estimate off by 6.7 percentage points, on the high side; the range from low to high includes it.
By their numbers in this assay, from the lowest: compounds 1, 3 and 2 (each within the scatter of the next).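

In this assay, 2-fluorophenyl in place of butyl on the aromatic carbon of the five-membered ring gives a number 3.8 percentage points lower from compound 2 to compound 3 (within the scatter), and 2-fluorophenyl in place of hexyl at the same carbon gives a number 0.2 percentage points higher from compound 1 to compound 3 (within the scatter). The earlier compounds had shown only one chain exchanged for another at this position, whereas these steps show that a six-membered aromatic ring of carbon can stand there in place of either chain with no change beyond the scatter, so among these three compounds the read-out does not separate a chain from this ring. Nothing available accounts for this lack of separation, and no further information on these compounds bears on it.

It remains open whether any group on this carbon would move the read-out beyond the scatter, such as an amine, a carboxylic acid or a longer chain, since all the groups shown so far leave the compounds indistinguishable. As far as these compounds go, whether the fluorine on the ring matters at all is also open, and a plain phenyl group at this carbon would speak to that question directly.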